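The source may hold more compounds than are shown below. What is called first, only, known or untested is meant among the compounds shown, and "the series" means these compounds.

Measured in a functional assay on SEM cells (Homo sapiens) for cytotoxicity, with a stated time of 72 h; on this read-out higher numbers stand for an effect only at larger amounts of compound and lower numbers for an effect already at smaller amounts:
Compound 1 `COc1ccc(/C=C/[C@@](C)(/C=C/c2ccc(O)c(C=O)c2)CCC=C(C)C)cc1`: 4550 nM.
Compound 2 `COc1ccc(/C=C/[C@@](C)(/C=C/c2ccc(O)c(/C=C/C(=O)OCc3ccccc3)c2)CCC=C(C)C)cc1`: > 36600 nM, which is a limit of the assay and not a number.
Compound 3 `COc1ccc(/C=C/[C@@](C)(/C=C/c2ccc(O)c(/C=C/C(=O)c3ccccc3)c2)CCC=C(C)C)cc1`: 36600 nM.

Compound 3 has the higher of the two true numbers, and the nearest number is that of compound 1 at 4550 nM. Compound 4 `COc1ccc(/C=C/[C@@](C)(/C=C/c2ccc(O)cc2)CCC=C(C)C)cc1` has not yet been measured. It carries hydrogen in place of 2-benzoylethenyl on an aromatic carbon, ortho to a hydroxy group: hydrogen in place of 2-benzoylethenyl on an aromatic carbon.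

Among the measured compounds shown here, two measured steps bear on this change: an 8.0-fold higher number from compound 1 to compound 3 (0.91 log units; beyond the scatter) and an at least 8.0-fold higher number from compound 1 to compound 2 (0.90 log units; beyond the scatter). In both, a larger group replaces the formyl of compound 1 and the number rises. For the measured compounds named here, no measured compound has hydrogen at this place, so these steps are only an indirect guide. Removing the large group is expected to reverse part of that rise, giving a modestly lower number in this assay. The expected step is a 2.6-fold lower number from compound 3 to compound 4 (0.42 log units; beyond the scatter). For compound 4 the estimated value is 14000 nM, with an expected range from 4000 nM to 40000 nM.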

Compound 4, half-maximal effective concentration: > 36600 nM
Compound 4: only a limit was reported (the forecaster's own chance of this, stated with the estimate: 15%); middle value at least 2.6-fold (0.41 log units) away from the limit.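

In this assay, hydrogen on this aromatic carbon, ortho to a hydroxy group, does not bring the number down: a number no lower from compound 3 to compound 4 (the limit leaves the size open). The step that can be read is an at least 8.0-fold higher number from compound 1 to compound 4 (0.90 log units; beyond the scatter), so among the compounds shown the lower number goes with the formyl of compound 1 alone, and the 2-benzoylethenyl and 2-(benzyloxycarbonyl)ethenyl groups are not needed for the higher numbers. The value of compound 4 is a limit of the assay, like that of compound 2, and the step between these two cannot be read: the limit of > 36600 nM in this assay, at which 2 of the 4 values shown sit.

As far as these compounds go, it remains open whether the formyl itself is required, or whether another group at this place, such as hydroxymethyl, acetyl or a carboxylic acid, would also give a number near that of compound 1. From the compounds shown here alone, how far compound 4 lies beyond its limit also stays open.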